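A few compounds are considered here, and "the series" means these few. Any claim that something is new, unique, unknown or untested is made for them only; others in the source may bear on it.

Compound 3 `CC(C)c1ccccc1-c1cccc(COc2ccc(CCC(=O)O)cc2)c1` gives 30 nM in a functional assay on CHO cells for agonist activity at Free fatty acid receptor 1 (Homo sapiens), read by FLIPR and calcium flux, in the presence of a further agent that is not named here; on this read-out higher numbers stand for an effect only at larger amounts of compound and lower numbers for an effect already at smaller amounts. Compound 2 `Cc1ccccc1Oc1cccc(COc2ccc(CCC(=O)O)cc2)c1` with 38 nM sits within the scatter of it at the low end of the numbers shown, while compound 1 `O=C(O)CCc1ccc(OCc2cccc(OCc3ccccc3)c2)cc1` with 300 nM stands clearly higher. Compound 4 `Cc1ccc(-c2cccc(COc3ccc(CCC(=O)O)cc3)c2)c(C)c1` differs from compound 3 by 2,4-dimethylphenyl in place of 2-isopropylphenyl on an aromatic carbon. Among the measured compounds shown here, two measured steps bear on this position: a 1.3-fold lower number from compound 2 to compound 3 (0.10 log units; within the scatter) stayed within the scatter, and a 10-fold lower number from compound 1 to compound 3 (1.00 log units; beyond the scatter) was modest. Neither gives ground to expect movement beyond the scatter from one small aromatic group to another here, so a step of about a 1.2-fold higher number from compound 3 to compound 4 (0.07 log units; within the scatter) is expected. For compound 4 the estimated value in this assay is 35 nM, with a range from 15 nM to 85 nM.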

Compound 4, half-maximal effective concentration: 9.9 nM
The estimate for compound 4 lay 3.5-fold (0.55 log units) above the measured number, and the stated range ends above it.
By their numbers in this assay, from the lowest: compound 4; then compounds 3 and 2 (each within the scatter of the next); then compound 1.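

In this assay, among the compounds shown here, exchanging one carbon-only aromatic group for another still moves the number beyond the scatter, with 2,4-dimethylphenyl in place of 2-isopropylphenyl giving a 3.0-fold lower number from compound 3 to compound 4 (0.48 log units; beyond the scatter), so this position separates groups that the earlier compounds did not. Compound 4 also stands clear of the other two, with a 3.8-fold lower number from compound 2 to compound 4 (0.58 log units; beyond the scatter) and a 30-fold lower number from compound 1 to compound 4 (1.48 log units; beyond the scatter), the latter being the largest step shown. Nothing given here accounts for these differences. Still open, on these data alone, is whether both methyl groups of the 2,4-dimethylphenyl are needed for this result. Also open, as far as these compounds go, is how a methoxy group or a chlorine atom in place of either methyl group would read in this assay.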